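The source may hold more compounds than are shown below. What is called first, only, known or untested is meant among the compounds shown, and "the series" means these compounds.

Compound 1, `CNC(=O)c1ccc(Oc2cccc(NC(=S)Nc3ccc(C)cc3)c2)nc1`: > 100000 nM
Compound 2, `CNC(=O)c1ccc(Oc2cccc(NC(=S)Nc3ccc(Br)c(C(F)(F)F)c3)c2)nc1`: 2670 nM

In a functional assay on PC-3 cells (Homo sapiens) for antiproliferative activity, read by MTT assay (a lower number here means a stronger inhibitor, a higher number a weaker inhibitor), compound 1 gives only a limit, > 100000 nM, and not a number. In this assay compound 2 gives 2670 nM. Among the compounds with values here, compound 2 therefore carries the only real number among the values shown; the other value is a limit, noted as the limit of > 100000 nM in this assay, at which 1 of the 2 values shown sits, and so the two cannot be compared as numbers. Compound 3, `CNC(=O)c1ccc(Oc2cccc(NC(=S)Nc3ccc(F)c(C(F)(F)F)c3)c2)nc1`, has not yet been measured. It differs from compound 2 in a single place: fluoro in place of bromo on an aromatic carbon. Within the data shown here, no step between two measured compounds of this kind is available, so the size of this change has to be guessed rather than read off. The step of a 2.2-fold higher number from compound 2 to compound 3 (0.35 log units; beyond the scatter) is expected to point toward weaker inhibition, of a size that may lie just beyond the usual scatter, although a result within it would not be surprising. For compound 3 the estimate in this assay is 6000 nM, with a likely range from 2000 nM to 25000 nM.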

Compound 3, half-maximal inhibitory concentration: 7950 nM
For compound 3 the middle estimate is 1.3-fold (0.12 log units) below the measured one; measured number inside the range.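

Within the data shown here, this is the first measured step at this position, the aromatic carbon ortho to a trifluoromethyl group and para to a large group. In this assay, fluoro in place of bromo gives a 3.0-fold higher number from compound 2 to compound 3 (0.47 log units; beyond the scatter), and since a higher number means a weaker inhibitor, the bromo compound is the stronger of this pair by a modest margin. The position therefore responds to the choice of halogen, yet compound 3 still gives a real number and not a limit, so activity does not vanish with the smaller atom in place, and nothing measured here says why the two halogens differ.

With only bromo and fluoro shown at this carbon, it remains open where a chloro, a methoxy or an amine would fall, and whether the trend follows the size of the atom or something else entirely. On these data alone, the trifluoromethyl group is also the same in compound 2 and compound 3, so its own contribution cannot be read, and how a nitrile or a plain hydrogen in its place would change the result stays unknown.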